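Chain-amine change on the weakest of three

This account rests on a few compounds, and the source may have more. Where it says the series, first, only, none or still open, it means among the compounds named here.

Of the compounds shown here, three have been measured in a functional assay on HCT-116 cells (Homo sapiens) for cytotoxicity, read by MTT assay, with a stated time of 2 days; a lower number here means a stronger inhibitor, a higher number a weaker inhibitor. Compound 1 `CCCCNc1nc(NCc2ccco2)c2ccccc2n1` gives 5470 nM, the highest of the three numbers. Compound 2 `CCCCNc1nc(NCc2ccco2)c2cccc(F)c2n1` gives 1330 nM, and compound 3 `CCCCNc1nc(NCc2ccco2)c2cc(F)ccc2n1` gives 4310 nM. The two measured steps both put fluoro in place of hydrogen on an aromatic carbon of the shared core: a 4.1-fold lower number from compound 1 to compound 2 (0.61 log units; beyond the scatter), whereas a 1.3-fold lower number from compound 1 to compound 3 (0.10 log units; within the scatter). Compound 1 thus stands at the weak end, nearest to compound 3 and furthest from compound 2.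

Compound 4 `CCN(CC)CCNc1nc(NCc2ccco2)c2ccccc2n1` differs from compound 1 elsewhere: diethylamino in place of ethyl on a saturated chain carbon, two bonds along the chain from a nitrogen on an aromatic ring. Among the measured compounds shown here, neither measured step touches the butylamino chain, so no step in the set bears on this change; the fluoro steps say nothing about a chain nitrogen. For the measured compounds named here, the only footing is the value of compound 1 itself. Lacking any comparable step, the expectation in this assay is a step of no clear direction, close to the scatter, so compound 4 is expected to give about 4500 nM, within 1200 nM to 17000 nM. That estimate means a 1.2-fold lower number from compound 1 to compound 4 (0.08 log units; within the scatter), a step that is expected to stay near the scatter. A wide range is kept, since nothing measured here constrains the chain change.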

Compound 4, half-maximal inhibitory concentration: 25900 nM
For compound 4 the middle estimate is 5.8-fold (0.76 log units) below the measured one, and the stated range ends below it.
By their numbers in this assay, from the lowest: compound 2; then compounds 3 and 1 (each within the scatter of the next); then compound 4.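

Among the compounds shown here, the butylamino chain is a position that matters in this assay: the change to (2-(diethylamino)ethyl)amino gives a 4.7-fold higher number from compound 1 to compound 4 (0.68 log units; beyond the scatter), the first step towards a weaker inhibitor. For the compounds shown here, the earlier changes were confined to fluoro on the shared core, where a 4.1-fold lower number from compound 1 to compound 2 (0.61 log units; beyond the scatter) was the only step beyond the scatter, so the series now holds a change in each of two places, and these two steps run in opposite directions. Nothing available accounts for the higher number at this chain position.

With a single chain change in hand, the step cannot be assigned to the chain nitrogen, to its two ethyl groups or to the larger group as a whole; a dimethylamino or morpholine end on the same chain, or a plain hexyl chain without a nitrogen, would help separate these. The compounds shown also leave open whether the fluoro of compound 2 would keep its lower number when paired with the 2-(diethylamino)ethyl chain of compound 4.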